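The compounds below may be only part of what the source reports. "The series", "measured", "known", "first", "only" and "open" are said of these compounds alone.

Measured in a functional assay on SW480 cells (Homo sapiens) for cytotoxicity, read by MTT assay, with a stated time of 72 h; on this read-out higher numbers stand for weaker inhibition and lower numbers for stronger inhibition:

- compound 1 `COc1ccc(C(CC(=O)N[C@@H](CC(C)C)B(O)O)NC(=O)c2ccccc2)cc1`: 1080 nM
- compound 2 `COc1ccc([C@H](CC(=O)N[C@@H](CC(C)C)B(O)O)NC(=O)c2ccccc2)cc1`: 1720 nM

Within the data shown here, on these numbers, compound 2 cannot be told apart from the only other measured member of the series. Among the measured compounds shown here, the single measured step is a 1.6-fold higher number from compound 1 to compound 2 (0.20 log units; within the scatter), and the one structural point behind it is the fact that one of compounds 1 and 2 is drawn with a defined configuration and the other without, at the place where they differ.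

Compound 3 `COc1ccc([C@@H](CC(=O)N[C@@H](CC(C)C)B(O)O)NC(=O)c2ccccc2)cc1` is the unmeasured partner of compound 2: the two compounds have the same atoms and bonds and differ only in configuration as drawn: 1 of 2 stereo elements differ; a stereocentre at a saturated chain carbon is drawn S in compound 2 and R in compound 3. Nothing leaves or enters, and only the stereocentre at a saturated chain carbon changes, from S to R.

For the measured compounds named here, only the one measured step bears on this change. Compound 1 has no configuration drawn at this carbon. If it is read as holding both forms, which the data do not establish, then the small size of a 1.6-fold higher number from compound 1 to compound 2 (0.20 log units; within the scatter) points to only a modest gap between them. The form in compound 3 would then be expected to give the lower number.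

The expected change in this assay is a 1.9-fold lower number from compound 2 to compound 3 (0.28 log units; within the scatter), a modest step toward stronger inhibition.

For compound 3, the estimated value is 900 nM, with an expected range of 350 nM to 2200 nM.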

Compound 3, half-maximal inhibitory concentration: 410 nM
Compound 3: middle estimate off by 2.2-fold (0.34 log units), on the high side, and the stated range covers the measured number.
By their numbers in this assay, from the lowest: compound 3; then compounds 1 and 2 (each within the scatter of the next).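

In this assay, the configuration at this saturated chain carbon now makes a readable difference: the change from S to R gives a 4.2-fold lower number from compound 2 to compound 3 (0.62 log units; beyond the scatter), whereas the earlier step between compounds 1 and 2 stayed within the scatter. Compound 3 also separates from the compound with no configuration drawn at this carbon, with a 2.6-fold lower number from compound 1 to compound 3 (0.42 log units; beyond the scatter), so the R form stands apart from both other drawings while compounds 1 and 2 still cannot be told apart. With the second stereocentre drawn the same and no atom or bond changed, the gap in this series belongs to the inversion at this one carbon alone: the fact that compounds 2 and 3 differ only in the configuration as drawn

Whether compound 1 actually holds both forms, and in what proportion, stays unsettled, so its value cannot be read as an average of the other two. On these data alone, it also stays open whether the gap between S and R at this carbon persists when the methoxy group is replaced by an amine or a carboxylic acid, or when the side chain on the boron-bearing carbon becomes a longer chain.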